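Trimming the Amide Substituent: Isobutyl to Isopropyl

A few compounds are considered here, and "the series" means these few. Any claim that something is new, unique, unknown or untested is made for them only; others in the source may bear on it.

Measured compounds:
compound 1 `Cc1cnc(CN2CC(=O)N(CC(C)C)c3c(Cl)nc(N)nc32)c(C)c1Br` — 140 nM
compound 2 `COc1c(C)cnc(CN2CC(=O)N(CC(C)C)c3c(Cl)nc(N)nc32)c1C` — 40 nM

In a functional assay on HT-29 cells (Homo sapiens) for inhibition (on this read-out higher numbers stand for weaker inhibition and lower numbers for stronger inhibition), compound 1 gives 140 nM and compound 2 gives 40 nM. Within the data shown here, the single measured step, a 3.5-fold lower number from compound 1 to compound 2 (0.54 log units; beyond the scatter), came from the methoxy in place of bromo on an aromatic carbon, and it places compound 2 at the lowest number of the two.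

Compound 3 `COc1c(C)cnc(CN2CC(=O)N(C(C)C)c3c(Cl)nc(N)nc32)c1C` differs from compound 2 by isopropyl in place of isobutyl on an amide-type nitrogen in a ring. Among the measured compounds shown here, no measured step touches this amide-type nitrogen; the step of a 3.5-fold lower number from compound 1 to compound 2 (0.54 log units; beyond the scatter) concerns the aromatic carbon and offers no guide to this change. With nothing to lean on, a step of no more than the usual scatter is expected in this assay, in either direction.

Compound 3 is therefore estimated at 50 nM in this assay, with a range from 18 nM to 140 nM. That estimate means an expected step of a 1.3-fold higher number from compound 2 to compound 3 (0.10 log units; within the scatter).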

Compound 3, half-maximal inhibitory concentration: 60 nM
Compound 3: middle estimate off by 1.2-fold (0.08 log units), on the low side; low and high end bracket the measured number.
By their numbers in this assay, from the lowest: compounds 2 and 3 (each within the scatter of the next); then compound 1.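

In this assay, among these compounds, isopropyl in place of isobutyl on the amide-type nitrogen gives a 1.5-fold higher number from compound 2 to compound 3 (0.18 log units; within the scatter), the first reading at this position, which the earlier pair did not touch. Within this pair, the assay does not separate the two branched chains, so the shortened chain is tolerated here. This holds only for compound 2 and compound 3, and it cannot be taken as a rule for the position as a whole. Nothing available speaks to the reason for this result. 

The compounds shown leave open how this nitrogen would respond to a group of another kind, such as an ethyl, a cyclopropyl ring, a longer chain or a chain ending in an amine. They also leave open whether the same swap would read alike with bromo rather than methoxy on the aromatic carbon.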